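This account rests on a few compounds, and the source may have more. Where it says the series, first, only, none or still open, it means among the compounds named here.

Of the compounds shown here, three of one series have been tested in a toxicity assay on MDCK cells (Canis lupus familiaris) for cytotoxicity, read by crystal violet staining, with a stated time of 48 h; a lower number here means that less compound is tolerated, a higher number that more compound is tolerated. Compound 1 `CCc1ccc2[nH]c(=O)c(CN(Cc3ccc(C(C)(C)C)cc3)[C@@H](C)c3ccc(OC)cc3)cc2c1` gives only a limit there: in this assay compound 1 reads > 5000 nM. Compound 2 `COc1ccc([C@H](C)N(Cc2ccc(C(C)(C)C)cc2)Cc2cc3cc(C(C)C)ccc3[nH]c2=O)cc1` likewise gives a limit, reading > 10000 nM in this assay. The step that the two limits leave unreadable from compound 1 to compound 2 therefore cannot be read, because both ends sit at a limit.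

Compound 3 `CC(c1ccc(N(C)C)c(Cl)c1)N(Cc1ccc(C(C)(C)C)cc1)Cc1cc2cc(C3CC3)ccc2[nH]c1=O` also stands at a limit: in this assay compound 3 reads > 10000 nM. It shares that position with one other compound, as the limit of > 10000 nM in this assay, at which 2 of the 3 values shown sit, shows, while the limit of > 5000 nM in this assay, at which 1 of the 3 values shown sits, marks where the third value sits. Going by the values given here, no numbered value exists in this assay for any of the three, so no step among them is readable in size.

Compound 4 `COc1ccc([C@H](C)N(Cc2ccc(C(C)(C)C)cc2)Cc2cc3cc(C4CC4)ccc3[nH]c2=O)cc1` differs from compound 3 by the change (1-(4-methoxyphenyl)ethyl in place of 1-(3-chloro-4-(dimethylamino)phenyl)ethyl on an amine nitrogen). Among the compounds with values here, the only measured step that touches this assay, the one from compound 1 to compound 2, is itself unreadable, so no size or direction can be drawn from it; what is known is that every tested compound has tolerated the highest concentration tried. On that basis compound 4 is expected to read 15000 nM in this assay, within 5000 nM to 50000 nM, and the step that the limit leaves unreadable from compound 3 to compound 4 is expected to be none beyond the scatter.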

Compound 4, half-maximal cytotoxic concentration: > 10000 nM
Compound 4: only a limit was reported; the forecaster's own chance of this, stated with the estimate: 85%; the middle value does not contradict the limit.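

In this assay compound 4 reads > 10000 nM, which is a limit and not a number. The steps to compound 4 from compound 1, compound 2 and compound 3 cannot be read, since all four values are limits. The compounds shown leave open where the half-maximal cytotoxic concentration of any of them lies, and whether any of these single changes shifts it.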